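This account rests on a few compounds, and the source may have more. Where it says the series, first, only, none or still open, it means among the compounds named here.

Measured so far in an ADME assay on J774 cells (Mus musculus) for cytotoxicity, read by MTT assay, with a stated time of 48 h; a lower number here means a stronger inhibitor, a higher number a weaker inhibitor:
- Compound 1 `[O-][n+]1onc2ccc(/C=C\[S+]([O-])c3ccccc3)cc21`: 14000 nM
- Compound 2 `[O-][n+]1onc2ccc(/C=C/[S+]([O-])c3ccc(Cl)cc3)cc21`: 18000 nM

These two values lie within the usual scatter of each other, so compound 2 cannot be told apart from compound 1. Going to compound 3 `[O-][n+]1onc2ccc(/C=C\[S+]([O-])c3ccc(Cl)cc3)cc21`, the change is the two compounds have the same atoms and bonds; at least one stereo element is drawn with a configuration in one of them and without one in the other: 1 of 2 stereo elements differ; a double bond is drawn E in compound 2 and Z in compound 3. A double bond is drawn E in compound 2 and Z in compound 3. Among the compounds with values here, no measured pair shows this change alone, so the only guide is compound 2 itself, at 18000 nM, and no change beyond the scatter is expected in this assay. The expected step is a 1.1-fold lower number from compound 2 to compound 3 (0.05 log units; within the scatter). For compound 3 the estimated value is 16000 nM, with an expected range of 7000 nM to 35000 nM.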

Compound 3, half-maximal inhibitory concentration: 10000 nM
Beside the measured number, compound 3's estimate is 1.6-fold (0.20 log units) above it; measured number inside the range.
By their numbers in this assay, from the lowest: compounds 3, 1 and 2 (each within the scatter of the next).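

Changing the double bond from E to Z gives a 1.8-fold lower number from compound 2 to compound 3 (0.26 log units; within the scatter) in this assay and so shows no effect that can be told from the scatter. Chloro in place of hydrogen on an aromatic carbon gives a 1.4-fold lower number from compound 1 to compound 3 (0.15 log units; within the scatter) and is equally unresolved, now on the Z series. The one structural point that bears on the first step concerns how the compounds are drawn: the fact that one of compounds 2 and 3 is drawn with a defined configuration and the other without, at the place where they differ

Still open, from the compounds shown here alone, is whether a different group on that aromatic carbon, such as an amine or a carboxylic acid, would move the number beyond the scatter.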